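This account rests on a few compounds, and the source may have more. Where it says the series, first, only, none or still open, it means among the compounds named here.

Compound 2 `O=C1N/C(=N/c2csc(-c3ccc(Cl)cc3)c2)S/C1=C\c1ccc(Br)cc1` has the lower of the two numbers recorded so far in a functional assay on SW-620 cells (Homo sapiens) for cytotoxicity, read by MTT assay, with a stated time of 72 h (on this read-out higher numbers stand for weaker inhibition and lower numbers for stronger inhibition), where compound 2 gives 700 nM. Going by the values given here, compound 1 `Cc1ccc(/C=C2\S/C(=N\c3csc(-c4ccc(Cl)cc4)c3)NC2=O)cc1` in this assay gives 1500 nM, and the single measured step, a 2.1-fold lower number from compound 1 to compound 2 (0.33 log units; beyond the scatter), concerns only bromo in place of methyl. Compound 3 `O=C1N/C(=N/c2csc(-c3ccc(Cl)cc3)c2)S/C1=C\c1ccccn1` carries pyridin-2-yl in place of 4-bromophenyl on a double-bonded chain carbon bound to a double-bonded ring carbon. Among the compounds with values here, no measured step touches this change, so the account expects a step of a 1.4-fold higher number from compound 2 to compound 3 (0.15 log units; within the scatter) that stays within the scatter. For compound 3 the estimate in this assay is 1000 nM, with a range from 350 nM to 3000 nM.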

Compound 3, half-maximal inhibitory concentration: > 50000 nM
Compound 3: only a limit was reported; the forecaster's own chance of this, stated with the estimate: 5%; at least 50-fold (1.69 log units) between middle value and limit.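

Compound 3 gives only a limit of the assay, not a number: the limit of > 50000 nM in this assay, at which 1 of the 3 values shown sits. Read against that limit, pyridin-2-yl in place of 4-bromophenyl gives an at least 71-fold higher number from compound 2 to compound 3 (1.85 log units; beyond the scatter), and pyridin-2-yl in place of 4-methylphenyl gives an at least 33-fold higher number from compound 1 to compound 3 (1.52 log units; beyond the scatter). The earlier step between bromo and methyl was modest, whereas exchanging the whole aromatic ring at this position changes the read-out far more. The compounds shown leave open whether a plain phenyl or a pyridin-3-yl here would keep a measurable number, so the loss cannot yet be tied to the ring nitrogen or to the absent bromo or methyl.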